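The source may report more compounds than this note shows. Statements on the series, on what has been measured and on what is new or still open speak of the compounds shown alone.

Measured so far in a physicochemical assay for solubility, read by HPLC, in phosphate buffer, measured as kinetic solubility, at pH 7.4 (a higher number here means a more soluble compound, a lower number a less soluble compound), are three compounds, with a fourth still to come.

- compound 1 `CCC(=O)c1cc(-c2ccc(S(N)(=O)=O)cc2)n(-c2ccc(Cl)cc2)n1` with 41900 nM
- compound 2 `NS(=O)(=O)c1ccc(-c2cc(C(=O)CC3CCC3)nn2-c2ccc(Cl)cc2)cc1` with 4300 nM
- compound 3 `NS(=O)(=O)c1ccc(-c2cc(C(=O)N3CC4CC4C3)nn2-c2ccc(Cl)cc2)cc1` with 36600 nM

The step of a 1.1-fold lower number from compound 1 to compound 3 (0.06 log units; within the scatter) leaves that pair level, and the step of an 8.5-fold higher number from compound 2 to compound 3 (0.93 log units; beyond the scatter) keeps compound 3 in the upper pair of the three.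

Compound 4 `CN(C(=O)c1cc(-c2ccc(S(N)(=O)=O)cc2)n(-c2ccc(Cl)cc2)n1)C1CC1` carries cyclopropyl(methyl)amino, the change being a group of 5 heavy atoms (4 carbon, 1 nitrogen; one three-membered non-aromatic ring of carbon only) in place of a group of 6 heavy atoms (5 carbon, 1 nitrogen; one three-membered non-aromatic ring of carbon only, one five-membered non-aromatic ring with 1 hetero atom), on a carbonyl carbon with the core untouched. Among the measured compounds shown here, no measured step makes this exact swap, so the other steps serve only as guides. The step of a 1.1-fold lower number from compound 1 to compound 3 (0.06 log units; within the scatter) brought in the leaving group with no shift beyond the scatter. The step of a 9.7-fold lower number from compound 1 to compound 2 (0.99 log units; beyond the scatter) is the one modest move to an all-carbon ring group, whereas the entering and leaving groups here both hold a nitrogen. No step beyond the scatter is therefore expected in this assay on this change. The estimated step is a 1.1-fold lower number from compound 3 to compound 4 (0.04 log units; within the scatter) in all. For compound 4 the expected value is 33000 nM within an estimated range of 14000 nM to 65000 nM in all.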

Compound 4, solubility: 99600 nM
For compound 4 the middle estimate is 3.0-fold (0.48 log units) below the measured one; measured number outside the range, above it.
By their numbers in this assay, from the lowest: compound 2; then compounds 3 and 1 (each within the scatter of the next); then compound 4.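

On the carbonyl carbon, the nitrogen-bearing group turns out not to be interchangeable in this assay: cyclopropyl(methyl)amino in place of the two-ring group gives a 2.7-fold higher number from compound 3 to compound 4 (0.43 log units; beyond the scatter), although compound 3 had stood level with compound 1. The same entering group gives a 2.4-fold higher number from compound 1 to compound 4 (0.38 log units; beyond the scatter) against ethyl and a 23-fold higher number from compound 2 to compound 4 (1.36 log units; beyond the scatter) against cyclobutylmethyl, leaving compound 4 with the highest number of the four, beyond the scatter of each of the others. Nothing available explains this difference between the two nitrogen-bearing groups.

The compounds shown leave open whether the rise follows the methyl on the nitrogen, the cyclopropyl group or the loss of the five-membered ring. A dimethylamino group, a cyclopropylamino group or a plain pyrrolidine on the same carbonyl carbon would begin to separate these.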